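Octyl chain in place of alkyne on the sulfonamide ring

The compounds below may be only part of what the source reports. "The series", "measured", "known", "first", "only" and "open" are said of these compounds alone.

Results in a functional assay on A-375 cells (Homo sapiens) for antiproliferative activity, read by trypan blue exclusion, with a stated time of 48 h, tested at 5 uM; a higher number here means a weaker effect of the compound at the concentration tested, a lower number a stronger effect:
compound 1 `CC(=O)Nc1nc(-c2cccc(NS(=O)(=O)c3ccc(C#CC4CCCCC4)cc3)c2)cs1` gives 1.2%
compound 2 `CC(=O)Nc1nc(-c2cccc(NS(=O)(=O)c3ccc(C#C[Si](C)(C)C)cc3)c2)cs1` gives 4.2%
compound 3 `CC(=O)Nc1nc(-c2cccc(NS(=O)(=O)c3ccc(C#CCCc4ccccc4)cc3)c2)cs1` gives 4.2%

Compound 3 stands level with compound 2 at the digits shown, and the remaining step is a number 3 percentage points higher from compound 1 to compound 3 (within the scatter); all three numbers are low and lie within the usual scatter of one another. The three measured steps, a number 3 percentage points higher from compound 1 to compound 2 (within the scatter), a number 3 percentage points higher from compound 1 to compound 3 (within the scatter) and no change at the digits printed from compound 2 to compound 3 (within the scatter), all swap the group on the triple-bonded carbon and none moves the read-out beyond the scatter.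

Compound 4 `CCCCCCCCc1ccc(S(=O)(=O)Nc2cccc(-c3csc(NC(C)=O)n3)c2)cc1` is not yet measured. It differs from compound 3 in this way: octyl in place of 4-phenylbut-1-yn-1-yl on an aromatic carbon. Going by the values given here, no measured step removes the triple bond itself, so this change is only loosely covered; what the steps do show is that varied groups at this end of the molecule left the read-out unchanged. The step to compound 4 is therefore expected to be a number 0.8 percentage points higher from compound 3 to compound 4 (within the scatter), within the scatter. Compound 4 is estimated at 5%, ranging from 0% to 20%.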

Compound 4, a percentage reported as activity, at one concentration (the size of the read-out at that concentration, not a potency): < 1%
Compound 4 gave a limit, no number (the forecaster's own chance of this, stated with the estimate: 5%); at least 4 percentage points between middle value and limit.
By their numbers in this assay, from the lowest: compounds 1, 2 and 3 (each within the scatter of the next). At a limit, below all of these: compound 4.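

In this assay compound 4 gives < 1%, which is a limit of the assay and not a number: the limit of < 1% in this assay, at which 1 of the 4 values shown sits. Compound 4 is the first of these compounds with no triple bond at this position, and its octyl chain has no ring, yet the read-out stays low: a number at least 3.2 percentage points lower from compound 3 to compound 4 (that floor lies within the scatter), a number at least 3.2 percentage points lower from compound 2 to compound 4 (that floor lies within the scatter) and a number at least 0.2 percentage points lower from compound 1 to compound 4 (that floor lies within the scatter). So in these four compounds, neither a triple bond nor a ring in the group on this aromatic carbon is needed for a low read-out, though the steps do not place compound 4 ahead of the others.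

On these data alone, it remains open how short the chain can become, as a butyl chain would show, and what an amine or a carboxylic acid at its end would do. A read-out at one concentration also leaves the potencies of these four compounds unresolved.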